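Longer saturated chains on the shared core

The compounds below may be only part of what the source reports. "The series", "measured", "known", "first", "only" and "open" are said of these compounds alone.

compound 1 `CCCCCCCCCCCSC[C@H](NC(C)=O)C(=O)CCl`: 3000 nM
compound 2 `CCCCCCCCCCCCCCCCCCSC[C@H](NC(C)=O)C(=O)CCl`: > 100000 nM

In a functional assay on MOLT-3 cells (Homo sapiens) (on this read-out higher numbers stand for weaker inhibition and lower numbers for stronger inhibition), compound 1 gives 3000 nM. For compound 2 in this assay only a limit is known, > 100000 nM. That reading sits at the limit of > 100000 nM in this assay, at which 1 of the 2 values shown sits. For the measured compounds named here, the one measured step, an at least 33-fold higher number from compound 1 to compound 2 (1.52 log units; beyond the scatter), runs upward and is large. Compound 3 `CCCCCCCCCCCCCCCCCCCCSC[C@H](NC(C)=O)C(=O)CCl` carries the change (ethyl in place of hydrogen on a saturated chain carbon, ten or more bonds along the chain from a sulfur), a further extension of the same chain. The step from compound 1 to compound 2 bears on it, but as compound 2 already rests on a limit, no direction beyond the limit can be resolved; the expected step is a step that the limit leaves unreadable from compound 2 to compound 3. Compound 3 is therefore expected at about 150000 nM in this assay, most likely again reported as a limit, within 50000 nM to 500000 nM.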

Compound 3, half-maximal inhibitory concentration: > 100000 nM
Compound 3 gave a limit, no number; the forecaster's own chance of this, stated with the estimate: 85%; the middle value lies beyond the limit too.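

In this assay, ethyl in place of hydrogen on a saturated chain carbon, ten or more bonds along the chain from a sulfur, brings no readable value back: compound 3 gives > 100000 nM, a limit and not a number. Taken from the shorter chain, the nonyl change gives an at least 33-fold higher number from compound 1 to compound 3 (1.52 log units; beyond the scatter), so the large rise also holds for the longest chain shown. The step from compound 2 to compound 3 cannot be read, and two of the chains now share one limit: the limit of > 100000 nM in this assay, at which 2 of the 3 values shown sit.

Open, on these data alone, is how the values run for chain lengths between those of compound 1 and compound 2. Also open, as far as these compounds go, is whether a shorter chain, or a chain carrying a carboxylic acid or an amine, gives a readable value.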